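Adding a Chlorine to the Bicyclic Ring of Compound 3

The compounds below may be only part of what the source reports. "The series", "measured", "known", "first", "only" and "open" are said of these compounds alone.

Compound 3 `O=C(Nc1nc2ccccc2s1)c1cn(-c2ccccc2)nc1-c1ccc(F)cc1` carries a fluoro group on one of its phenyl rings. Among the compounds with values here, in a functional assay on U-87MG ATCC cells for cytotoxicity against U-87 MG (Homo sapiens), read by MTT assay, with a stated time of 72 h (on this read-out higher numbers stand for weaker inhibition and lower numbers for stronger inhibition), compound 3 gives 10700 nM, the second highest of the three numbers measured so far. Its nearest neighbour is compound 1 `O=C(Nc1nc2ccccc2s1)c1cn(-c2ccccc2)nc1-c1ccccc1`, which gives 8960 nM; the step of a 1.2-fold higher number from compound 1 to compound 3 (0.08 log units; within the scatter) stays within the scatter, so the two cannot be told apart. Compound 2 `Cc1ccc2nc(NC(=O)c3cn(-c4ccccc4)nc3-c3ccccc3)sc2c1` gives 23200 nM, the highest number of the three.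

Compound 4 `O=C(Nc1nc2ccc(Cl)cc2s1)c1cn(-c2ccccc2)nc1-c1ccc(F)cc1` differs from compound 3 by chloro in place of hydrogen on an aromatic carbon. Within the data shown here, the only measured step that touches the same bicyclic ring system is a 2.6-fold higher number from compound 1 to compound 2 (0.41 log units; beyond the scatter), a modest loss of potency when a substituent enters there. One step is thin ground, and the chloro group enters at its own position, but it is the closest guide available. On that basis the expected step is a 1.5-fold higher number from compound 3 to compound 4 (0.17 log units; within the scatter), a mild weakening at most, possibly nothing beyond the scatter. The estimate for compound 4 is 16000 nM, with a range from 6500 nM to 40000 nM.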

Compound 4, half-maximal inhibitory concentration: 6770 nM
Estimate against measurement, compound 4: 2.4-fold (0.37 log units) above; measured number inside the range.
By their numbers in this assay, from the lowest: compounds 4, 1 and 3 (each within the scatter of the next); then compound 2.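

The chloro group of the 6-chloro-1,3-benzothiazol-2-yl unit brings a 1.6-fold lower number from compound 3 to compound 4 (0.20 log units; within the scatter) in this assay, so compound 3 and compound 4 cannot be told apart, and a single chlorine on this six-membered ring leaves the number within the scatter. That differs from the only other substitution shown on this ring, a 2.6-fold higher number from compound 1 to compound 2 (0.41 log units; beyond the scatter), which lies beyond the scatter; adding a substituent to this ring therefore does not always shift the number beyond the scatter, although the methyl and chloro steps start from different compounds. Nothing measured here explains this difference between the two steps.

From the compounds shown here alone, it remains open whether chloro would give a similar step on compound 1, which lacks the fluoro group. It is also unclear whether an amine or a carboxylic acid on this ring would move the number beyond the scatter, and in which direction.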